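The compounds below may be only part of what the source reports. "The series", "measured", "known", "first", "only" and "open" are said of these compounds alone.

Within the data shown here, in an ADME assay on HeLa cells (Homo sapiens) for cytotoxicity, read by resazurin assay, with a stated time of 2 days (on this read-out higher numbers stand for weaker inhibition and lower numbers for stronger inhibition), compound 1 `Cc1ccc(C(Br)C(Br)c2ncc([N+](=O)[O-])n2C)cc1` gives 11200 nM and this is the only exact number available so far. Compound 2 `Cn1c([N+](=O)[O-])cnc1/C=C/c1ccsc1` reads > 100000 nM in the same test, which is a limit of the assay and not a number. The next compound to be tested is compound 3 `Cn1c([N+](=O)[O-])cnc1C(Br)C(Br)c1ccc(Br)cc1` which has bromo in place of methyl on an aromatic carbon of the six-membered ring, para to a large group bromo in place of methyl on an aromatic carbon and otherwise matches compound 1. Among the measured compounds shown here, no measured step between closely matched compounds is available as a guide, so the expectation rests on compound 1 at 11200 nM and on how small the change is. The estimated 1.2-fold lower number from compound 1 to compound 3 (0.09 log units; within the scatter) is small, leaning slightly toward lower numbers and staying about within the usual scatter. For compound 3 the expected value is 9000 nM with an estimated range from 3500 nM to 25000 nM in this test.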

Compound 3, half-maximal inhibitory concentration: 7940 nM
Estimate against measurement, compound 3: 1.1-fold (0.05 log units) above, and the stated range covers the measured number.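

In this assay, bromo in place of methyl on an aromatic carbon, para to a large group, gives a 1.4-fold lower number from compound 1 to compound 3 (0.15 log units; within the scatter) in this test. Among these compounds, this is the first step between closely matched compounds here, and it shows that the exchange of these two groups at this place leaves the read-out within the scatter, which a single exact number could not show. Nothing measured here gives a reason for this step, and none of what is shown bears on it.

On these data alone, whether an amine, a carboxylic acid or a longer chain at this same place would move the number beyond the scatter stays open. Also open, as far as these compounds go, is whether bromo in place of methyl would give a similar step on any other core.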